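A few compounds are considered here, and "the series" means these few. Any claim that something is new, unique, unknown or untested is made for them only; others in the source may bear on it.

Compounds measured so far in an in vitro assay on Sf21 cells for inhibition of high affinity 3',5'-cyclic-AMP phosphodiesterase 7A (Homo sapiens); on this read-out higher numbers stand for weaker inhibition and lower numbers for stronger inhibition:

- Compound 1, `CNc1nc(NC2(C#N)CCCCC2)nc(-n2ccnc2)n1`: 1050 nM
- Compound 2, `CNc1nc(NC2(C#N)CCCCC2)nc(N(C)C)n1`: > 5000 nM, which is a limit of the assay and not a number
- Compound 3, `CNc1nc(N)nc(NC2(C#N)CCCCC2)n1`: "not determined" (no result reported)

Compound 3 therefore stands nowhere on the numbers shown: no result was reported for it, so it cannot be placed against the other two. Compound 4, `CNc1nc(NC2(C#N)CCCCC2)nc(C2CC2)n1`, is the next one to be tested. It differs from compound 3 by cyclopropyl in place of amino on an aromatic carbon. Going by the values given here, only one measured step exists in this set, an at least 4.7-fold higher number from compound 1 to compound 2 (0.67 log units; beyond the scatter), and it concerns a different swap on the shared core, so it bears on the new change only loosely: it shows that exchanging a group on that aromatic carbon can move the read-out beyond the scatter, and there it moved toward weaker inhibition, ending at the limit noted for compound 2 (the limit of > 5000 nM in this assay, at which 1 of the 3 values shown sits). Among the compounds with values here, with compound 3 unmeasured and no directly comparable step, the direction for compound 4 is uncertain, and a wide range is expected. The estimate for compound 4 in this assay is 2000 nM, between 300 nM and 10000 nM.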

Compound 4, half-maximal inhibitory concentration: 539 nM
Estimate against measurement, compound 4: 3.7-fold (0.57 log units) above, and the stated range covers the measured number.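

In this assay, this aromatic carbon, opposite the ring nitrogen, accepts a small carbon-only ring about as well as it accepts 1H-imidazol-1-yl: there is a 1.9-fold lower number from compound 1 to compound 4 (0.29 log units; within the scatter), so these two groups cannot be ranked. Dimethylamino now stands apart from both groups, with an at least 9.2-fold lower number from compound 2 to compound 4 (0.96 log units; beyond the scatter). The value of compound 2 is a limit of the assay and not a number: the limit of > 5000 nM in this assay, at which 1 of the 4 values shown sits.

Going by these compounds, the step from compound 3 to compound 4 cannot be read, so how the small amino group compares with cyclopropyl remains unknown. On these data alone, it also remains open whether dimethylamino falls short through its nitrogen or through its shape, which a cyclic amine such as pyrrolidine, a plain isopropyl group or a methoxy group at the same carbon could help to separate.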